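A Shorter Side Chain on a Shared Core

A few compounds are considered here, and "the series" means these few. Any claim that something is new, unique, unknown or untested is made for them only; others in the source may bear on it.

Compound 1 `COc1ccc(N(C)c2nc(C)nc3ccccc23)cc1OCCCCCC[Se]C#N` and compound 2 `COc1ccc(N(C)c2nc(C)nc3ccccc23)cc1C(=O)NCC[Se]C#N` share one core and differ only in the side chain on one aromatic carbon. In a functional assay on RKO cells (Homo sapiens) for inhibition, read by MTT assay, with a stated time of 48 h (a higher number here means a weaker inhibitor, a lower number a stronger inhibitor), compound 1 gives 1540 nM, and compound 2 gives 1170 nM. These two values lie within the scatter of each other, because a 1.3-fold lower number from compound 1 to compound 2 (0.12 log units; within the scatter) is a small step. Compound 3 `COc1ccc(N(C)c2nc(C)nc3ccccc23)cc1C[Se]C#N` carries a group of 4 heavy atoms (2 carbon, 1 nitrogen, 1 selenium; no ring) in place of a group of 8 heavy atoms (4 carbon, 2 nitrogen, 1 oxygen, 1 selenium; no ring), on an aromatic carbon. Because a 1.3-fold lower number from compound 1 to compound 2 (0.12 log units; within the scatter) stayed within the scatter when the side chain at this position was exchanged, no shift beyond the scatter is expected here. For compound 3 the expected step is a 1.1-fold higher number from compound 2 to compound 3 (0.05 log units; within the scatter). Compound 3 is estimated at 1300 nM, between 500 nM and 3500 nM.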

Compound 3, half-maximal inhibitory concentration: 316 nM
Estimate against measurement, compound 3: 4.1-fold (0.61 log units) above; the measured number lies below the stated range.
By their numbers in this assay, from the lowest: compound 3; then compounds 2 and 1 (each within the scatter of the next).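

In this assay this position does respond to a change of side chain: compounds 1 and 2 stay within the scatter of each other, yet the group of 4 heavy atoms gives a stronger inhibitor (a 3.7-fold lower number from compound 2 to compound 3 (0.57 log units; beyond the scatter)) (a 4.9-fold lower number from compound 1 to compound 3 (0.69 log units; beyond the scatter)). Shortening alone does not always shift the number, since the shorter side chain of compound 2 brings no change beyond the scatter from compound 1. Nothing measured here explains the gain.

As far as these compounds go, what remains open is how an amine or a carboxylic acid at this position would compare with compound 3.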